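From trifluoroethoxy to carbamoyl in the series

A few compounds are considered here, and "the series" means these few. Any claim that something is new, unique, unknown or untested is made for them only; others in the source may bear on it.

In a functional assay on HeLa cells (Homo sapiens) for antiproliferative activity, read by CCK-8 assay, with a stated time of 72 h (a lower number here means a stronger inhibitor, a higher number a weaker inhibitor), compound 1 (`COc1ccc(-c2cncnc2-c2cc(OC)c(OC)c(OC)c2)cc1O`) gives 280 nM as its half-maximal inhibitory concentration. Compound 2 (`COc1cc(-c2ncncc2-c2ccc(OCC(F)(F)F)cc2)cc(OC)c1OC`) gives 10200 nM and holds the higher of the two numbers, a gap beyond the scatter. Compound 3 (`COc1cc(-c2ncncc2-c2ccc(C(N)=O)cc2)cc(OC)c1OC`) keeps the core of compound 2 but has carbamoyl in place of 2,2,2-trifluoroethoxy on an aromatic carbon. Within the data shown here, no measured step isolates this change, so the expectation is weakly grounded. The lower number of compound 1 at 280 nM shows only that the series can reach well under the value of compound 2. A moderate fall in this assay is expected, just beyond the scatter (a 2.9-fold lower number from compound 2 to compound 3 (0.46 log units; beyond the scatter)). For compound 3 the estimated value is 3500 nM with an expected range from 700 nM to 15000 nM in this read-out.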

Compound 3, half-maximal inhibitory concentration: > 100000 nM
Compound 3 was reported as a limit; the forecaster's own chance of this, stated with the estimate: 15%; middle value at least 28-fold (1.45 log units) from the limit.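

Among these compounds, at the aromatic carbon para to a large group, carbamoyl in place of 2,2,2-trifluoroethoxy gives an at least 9.8-fold higher number from compound 2 to compound 3 (0.99 log units; beyond the scatter) in this assay, the first single-place step at this position, and it runs towards the weaker end of the series. With 4-carbamoylphenyl in place of 3-hydroxy-4-methoxyphenyl, the change is an at least 350-fold higher number from compound 1 to compound 3 (2.55 log units; beyond the scatter), which widens the spread of the series well past the gap seen between the two earlier compounds. The value of compound 3 is a limit and not a number: the limit of > 100000 nM in this assay, at which 1 of the 3 values shown sits.

Open, as far as these compounds go, is whether an amine, a carboxylic acid or a longer chain at this position would give a measurable value in this assay. Also open, from the compounds shown here alone, is how far above the limit compound 3 lies, so the true size of both steps stays unknown.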